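Aryl Swap on a Boron-Containing Chalcone Series

This account rests on a few compounds, and the source may have more. Where it says the series, first, only, none or still open, it means among the compounds named here.

Measured so far:
Compound 1, `O=C(/C=C/c1ccc2c(c1)B(O)OC2)c1ccco1`, gives 24100 nM.
Compound 2, `O=C(/C=C/c1ccc2c(c1)B(O)OC2)c1ccc(Br)cc1`, gives 9900 nM.

Both numbers come from a functional assay on HCT-116 cells (Homo sapiens) for cytotoxicity, read by MTT assay, with a stated time of 48 h; on this read-out higher numbers stand for weaker inhibition and lower numbers for stronger inhibition. Within the data shown here, compound 2 stands as the lower of the two numbers, and the only measured step, a 2.4-fold lower number from compound 1 to compound 2 (0.39 log units; beyond the scatter), describes its separation from compound 1.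

Compound 3, `Cc1cccc(C(=O)/C=C/c2ccc3c(c2)B(O)OC3)c1`, is the next case. Its difference from compound 2 is 3-methylphenyl in place of 4-bromophenyl on a carbonyl carbon. Among the measured compounds shown here, the one measured step concerns a different exchange, a five-membered ring for a six-membered one, so it does not speak directly to trading one six-membered aromatic ring for another that is otherwise alike. For the measured compounds named here, with no step that bears on this change, the expectation is a number close to that of compound 2, and the estimated step is a 1.2-fold higher number from compound 2 to compound 3 (0.08 log units; within the scatter), not beyond the scatter. Compound 3 is therefore expected to give about 12000 nM, with a range from 5000 nM to 30000 nM.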

Compound 3, half-maximal inhibitory concentration: 6700 nM
For compound 3 the middle estimate is 1.8-fold (0.25 log units) above the measured one, within the range that was stated.
By their numbers in this assay, from the lowest: compounds 3 and 2 (each within the scatter of the next); then compound 1.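

Putting 3-methylphenyl in place of 4-bromophenyl gives a 1.5-fold lower number from compound 2 to compound 3 (0.17 log units; within the scatter) and so shows that these two six-membered aromatic rings cannot be told apart at this carbonyl carbon, meaning bromine is not needed to reach this level. Putting 3-methylphenyl in place of furan-2-yl gives a 3.6-fold lower number from compound 1 to compound 3 (0.56 log units; beyond the scatter) and so places both six-membered rings beyond the scatter from the five-membered ring, with none of the three compounds going against this. Nothing measured here explains these differences.

Compound 2 and compound 3 differ both in the group on the ring and in its numbered place, so these two changes cannot be separated. From the compounds shown here alone, whether an amine or a carboxylic acid on the six-membered ring would move the number also remains open.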